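A few compounds are considered here, and "the series" means these few. Any claim that something is new, unique, unknown or untested is made for them only; others in the source may bear on it.

Working notes on the series. Compound 2 `Nc1scc(CN2CCN(c3ccccc3F)CC2)c1C(=O)c1ccc(Cl)cc1` in a functional assay on CHO cells with adenosine receptor A1 (Homo sapiens) as the target, read by cAMP accumulation and immunoassay, with a stated time of 6 min, tested at 0.1 uM (on this read-out lower numbers stand for a stronger effect and higher numbers for a weaker effect at the one concentration tested), reads -1%, and compound 1 `Nc1scc(CN2CCN(c3ccccc3C(F)(F)F)CC2)c1C(=O)c1ccc(Cl)cc1` in this assay reads -7.5%; the two stand within the scatter of each other. Going by the values given here, the only measured step, a number 6.5 percentage points higher from compound 1 to compound 2 (within the scatter), lies within the scatter. Compound 3 `Nc1scc(CN2CCN(c3ccc(Cl)c(Cl)c3)CC2)c1C(=O)c1ccc(Cl)cc1` differs from compound 2 by 3,4-dichlorophenyl in place of 2-fluorophenyl on an amine nitrogen in a ring. Among the compounds with values here, no measured step touches this place or this pair of groups, so the step from compound 1 to compound 2 is only a loose guide. The expected step is a number 2 percentage points lower from compound 2 to compound 3 (within the scatter), none beyond the scatter. Compound 3 is estimated at -3%, with a range from -16% to 10%.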

Compound 3, a percentage reported as activity, at one concentration (the size of the read-out at that concentration, not a potency): -13%
For compound 3 the middle estimate is 10 percentage points above the measured one; low and high end bracket the measured number.
By their numbers in this assay, from the lowest: compounds 3, 1 and 2 (each within the scatter of the next, the first and the last beyond it).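

Going by these compounds alone, at the amine nitrogen in a ring, the exchange for 3,4-dichlorophenyl gives the only step beyond the scatter so far in this assay, a number 12 percentage points lower from compound 2 to compound 3 (beyond the scatter), a modest one. Starting from 2-(trifluoromethyl)phenyl, the same entering group gives a number 5.5 percentage points lower from compound 1 to compound 3 (within the scatter), so this position separates only compound 2 from compound 3. No available evidence bears on the origin of this step.

Open, on these data alone, is how an aryl ring carrying an amine or a carboxylic acid would read at this position. Also open, as far as these compounds go, is whether a longer chain on this nitrogen would keep the step.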